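Moving the methyl on the anilide ring of compound 2

The compounds below may be only part of what the source reports. "The series", "measured", "known", "first", "only" and "open" are said of these compounds alone.

Measured compounds:
- compound 1 `O=C(O)CCc1nnc(C(=O)Nc2ccc(OCc3ccccc3)cc2)s1`, in a functional assay on CHO cells for agonist activity at Free fatty acid receptor 1 (Homo sapiens), read by calcium flux (a lower number here means that less compound is needed, a higher number that more compound is needed for the effect), compound 1 gives 17900 nM
- compound 2 `Cc1cccc(NC(=O)c2nnc(COc3ccc(CCC(=O)O)cc3)s2)c1`, in this assay compound 2 gives 1770 nM

Compound 2 stands lowest of the two numbers. Its nearest neighbour is compound 1, whose value lies well beyond the scatter above that of compound 2, although the two differ in more than one place, so nothing more than the two values themselves can be read from that pair.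

Compound 3 `Cc1ccc(NC(=O)c2nnc(COc3ccc(CCC(=O)O)cc3)s2)cc1` is not yet measured. It is built from compound 2 by the change (4-methylphenyl in place of 3-methylphenyl on an amide-type nitrogen); the two have the same atoms, joined differently, and only the substituent on the amide nitrogen is affected. Going by the values given here, no measured pair shows what such a change does here, so the size and direction of the step are open. The expectation is that the step of a 1.4-fold higher number from compound 2 to compound 3 (0.15 log units; within the scatter) stays within the usual scatter or only a little beyond it. Compound 3 is therefore estimated at 2500 nM, with a range from 800 nM to 8000 nM in this assay.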

Compound 3, half-maximal effective concentration: 4300 nM
The estimate for compound 3 lay 1.7-fold (0.24 log units) below the measured number; low and high end bracket the measured number.
By their numbers in this assay, from the lowest: compound 2; then compound 3; then compound 1.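

Moving the methyl from 3-methylphenyl to 4-methylphenyl on the amide nitrogen changes the result in this assay, with a 2.4-fold higher number from compound 2 to compound 3 (0.39 log units; beyond the scatter). Going by these compounds alone, this is the first pair that differs in one place, and it shows that the substituent on the amide nitrogen is sensitive to where the methyl sits, even though the atoms stay the same: of these two groups, 3-methylphenyl goes with the lower number, and the step, though modest, lies beyond the usual scatter. No measurement is available here that would explain this shift.

The compounds shown leave open whether a plain phenyl on the amide nitrogen would give a lower or a higher number than either methyl compound, and whether a chlorine or a methoxy group in place of the methyl would show the same order between these two ring positions. They also leave open whether this order would hold if the propanoic acid chain of compound 2 and compound 3 were replaced by a longer carboxylic acid chain.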